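Trifluoromethoxy to trifluoromethyl in two cytotoxicity pairs

The compounds below may be only part of what the source reports. "The series", "measured", "known", "first", "only" and "open" are said of these compounds alone.

Compound 1 `CCOC(=O)c1c(-c2cccc(OC(F)(F)F)c2)[nH]c2cc(OC)ccc2c1=O` and compound 2 `CCOC(=O)c1c(-c2cccc(C(F)(F)F)c2)[nH]c2cc(OC)ccc2c1=O` differ by trifluoromethyl in place of trifluoromethoxy on an aromatic carbon. In an ADME assay on BJ cells (Homo sapiens) for cytotoxicity, read by luminescence, with a stated time of 72 h (a lower number here means that less compound is needed, a higher number that more compound is needed for the effect), compound 1 gives only a limit, > 21500 nM. Compound 2 likewise gives only a limit in this assay, > 21500 nM. Between them, a step that the two limits leave unreadable from compound 1 to compound 2. Compound 3 `CCOC(=O)c1c(-c2cccc(OC)c2)[nH]c2cc(OC(F)(F)F)ccc2c1=O` has the same atoms as compound 1 joined differently; the difference between the two cores is not broken down here. In this assay compound 3 also gives only a limit, > 21500 nM. Going by the values given here, all values so far sit at the limit of > 21500 nM in this assay, at which 3 of the 3 values shown sit. Compound 4 `CCOC(=O)c1c(-c2cccc(OC)c2)[nH]c2cc(C(F)(F)F)ccc2c1=O` is not yet measured; it differs from compound 3 by trifluoromethyl in place of trifluoromethoxy on an aromatic carbon. This is the same kind of change as that from compound 1 to compound 2, but its place differs: in compound 3 the aromatic carbon lies on a six-membered aromatic ring of carbon only, part of a fused or bridged system of two rings, meta to a fused ring and para to a fused ring, whereas in compound 1 it is meta to a large group. Because every value shown sits at the limit of > 21500 nM in this assay, at which 3 of the 3 values shown sit, the step that the limit leaves unreadable from compound 3 to compound 4 is expected to be negligible. Compound 4 is estimated at 30000 nM, between 21500 nM and 100000 nM, most probably reported again only as a limit.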

Compound 4, half-maximal effective concentration: > 21500 nM
Compound 4: a limit, no number (the forecaster's own chance of this, stated with the estimate: 85%); the middle value is on the limit's open side.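

In this assay compound 4 gives > 21500 nM, which is a limit and not a number. Compound 3 also stands at a limit, so no step can be read from compound 3 to compound 4: the limit of > 21500 nM in this assay, at which 4 of the 4 values shown sit.

The compounds shown leave open whether trifluoromethyl in place of trifluoromethoxy alters the read-out at either place, and what true values lie behind the four limits.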